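Aryl semicarbazone series: whole-animal read-out, one substitution

The source may hold more compounds than are shown below. What is called first, only, known or untested is meant among the compounds shown, and "the series" means these compounds.

Measured so far:
- compound 1 `O=C(N/N=C/c1ccc(Br)cc1)Nc1cccc2ccccc12`: 300 mg/kg
- compound 2 `C/C(=N\NC(=O)Nc1cccc2ccccc12)c1ccc(C)cc1`: 300 mg/kg

Both measured compounds were tested in a functional assay on the whole organism (strain Swiss albino) with Mus musculus as the target, with a stated time of 0.5 h; on this read-out lower numbers stand for an effect already at smaller amounts and higher numbers for an effect only at larger amounts of compound. Compound 1 gives 300 mg/kg, and compound 2 gives 300 mg/kg; the two values are level at the digits shown, within the scatter, so compound 1 stands together with compound 2 and no order between them can be read. For the measured compounds named here, no step between measured compounds is available that would show how a change on the aryl end of the shared core moves the read-out.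

Compound 3 `O=C(N/N=C/c1ccccc1Cl)Nc1cccc2ccccc12` is the next member, not yet measured in this assay. It differs from compound 1 as follows: 2-chlorophenyl in place of 4-bromophenyl on a carbon with a double bond to nitrogen. The change keeps the same count of heavy atoms and the same ring type, with a halogen exchanged and moved within the entering group.

Going by the values given here, with only two level values to go on, the expectation for compound 3 is no step beyond the scatter, no change at the digits printed from compound 1 to compound 3 (within the scatter). Compound 3 is therefore estimated at 300 mg/kg, in the range 150 mg/kg to 600 mg/kg.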

Compound 3, minimum effective dose: 300 mg/kg
Compound 3: middle estimate and measured number agree at the digits printed; the range from low to high includes it.
By their numbers in this assay, from the lowest: compounds 1, 2 and 3 (each within the scatter of the next).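

In this assay, the series now has its first readable step at this place: 2-chlorophenyl in place of 4-bromophenyl on a carbon with a double bond to nitrogen gives no change at the digits printed from compound 1 to compound 3 (within the scatter). A halogen exchanged and moved within the entering group therefore leaves the read-out level, which the two earlier values alone could not show for any change at this place. Nothing measured here accounts for this flat step.

The exchange of halogen and its move are joined in this single step, so neither can be read by itself. Going by these compounds, whether an amine or a carboxylic acid on the phenyl ring, in place of the halogen, would give a step beyond the scatter remains open.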